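Swapping the Aryl Group on Three Compounds at the Limit

The source may report more compounds than this note shows. Statements on the series, on what has been measured and on what is new or still open speak of the compounds shown alone.

Compound 3 `O=c1ccoc2cc(OCc3cn(Cc4cccc(F)c4)nn3)ccc12` was examined in a functional assay on QGY7701 cells (Homo sapiens) for cytotoxicity, read by MTT assay, with a stated time of 48 h; a higher number here means a weaker inhibitor, a lower number a stronger inhibitor. In this assay compound 3 gives > 100000 nM, which is a limit of the assay and not a number. Its two measured neighbours are compound 1 `O=c1ccoc2cc(OCc3cn(Cc4ccccc4)nn3)ccc12` and compound 2 `Cc1ccccc1Cn1cc(COc2ccc3c(=O)ccoc3c2)nn1`. In this assay compound 1 gives > 100000 nM, again a limit. In this assay compound 2 gives > 100000 nM, also a limit. Going by the values given here, because of the limit of > 100000 nM in this assay, at which 3 of the 3 values shown sit, none of the measured steps can be read: a step that the two limits leave unreadable from compound 1 to compound 2, a step that the two limits leave unreadable from compound 1 to compound 3 and a step that the two limits leave unreadable from compound 2 to compound 3 all run between limits. Compound 4 `O=c1ccoc2cc(OCc3cn(Cc4ccc([N+](=O)[O-])cc4)nn3)ccc12` is the compound still to be measured. It differs from compound 3 in one place: 4-nitrophenyl in place of 3-fluorophenyl on a saturated chain carbon bound to an aromatic nitrogen. Among the compounds with values here, the measured step that most resembles this change, exchanging the whole ring on the saturated chain carbon bound to an aromatic nitrogen, is the one from compound 2 to compound 3, and it too sits between two limits. Nothing in these three compounds shows that varying this ring moves the number at all, so compound 4 is expected to remain at or near the limit. The change therefore expected is a step that the limit leaves unreadable from compound 3 to compound 4. For compound 4 in this assay the estimate is 200000 nM, with a range from 60000 nM to 600000 nM.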

Compound 4, half-maximal inhibitory concentration: > 100000 nM
Compound 4 ended at the assay's limit; the forecaster's own chance of this, stated with the estimate: 80%; the middle value lies beyond the limit too.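

Compound 4 ends at a limit of the assay and not at a number, so its steps to compound 1, compound 2 and compound 3 cannot be read, since all four compounds sit at the same limit: the limit of > 100000 nM in this assay, at which 4 of the 4 values shown sit.

The compounds shown leave open whether any change to the aryl ring on the saturated chain carbon bound to an aromatic nitrogen affects the result in this assay.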